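Chloro in Place of Methoxy on a Fluorinated Amide

A few compounds are considered here, and "the series" means these few. Any claim that something is new, unique, unknown or untested is made for them only; others in the source may bear on it.

In a functional assay on PC-3 cells (Homo sapiens) for cytotoxicity, read by MTT assay, with a stated time of 72 h (a lower number here means a stronger inhibitor, a higher number a weaker inhibitor), compound 2, `COc1ccc(-c2ccc(C(=O)Nc3ccc(Oc4ccnc5[nH]ccc45)c(F)c3)nc2)cc1`, gives 650 nM, the only numerical result among the compounds shown. Compound 1, `O=C(Nc1ccc(Oc2ccnc3[nH]ccc23)cc1)c1ccc(-c2ccc(Cl)cc2)cn1`, reaches only a limit there, > 10000 nM; this is the limit of > 10000 nM in this assay, at which 1 of the 2 values shown sits. Compound 3, `O=C(Nc1ccc(Oc2ccnc3[nH]ccc23)c(F)c1)c1ccc(-c2ccc(Cl)cc2)cn1`, has not yet been measured. It differs from compound 2 by chloro in place of methoxy on an aromatic carbon. Among the measured compounds shown here, no single-change step between measured compounds is available, so the direction must be judged from the two results alone. The step of a 4.6-fold higher number from compound 2 to compound 3 (0.66 log units; beyond the scatter) is expected to run toward weaker inhibition, and a limit rather than a number would not be surprising. Compound 3 is estimated at 3000 nM, between 700 nM and 15000 nM.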

Compound 3, half-maximal inhibitory concentration: 3030 nM
The estimate for compound 3 lay 1.0-fold (0.00 log units) below the measured number; the measured number falls inside the stated range.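

The change from 4-methoxyphenyl to 4-chlorophenyl has a real cost in this assay, with a 4.7-fold higher number from compound 2 to compound 3 (0.67 log units; beyond the scatter). With chloro kept in place, fluoro in place of hydrogen gives an at least 3.3-fold lower number from compound 1 to compound 3 (0.51 log units; beyond the scatter), so the chloro compound now has a measured number. Compound 1 stands at a limit, not a number: the limit of > 10000 nM in this assay, at which 1 of the 3 values shown sits.

Still open, as far as these compounds go, is how an amine or a carboxylic acid would read in place of the chloro. Also open, from the compounds shown here alone, is whether the fluoro step would hold with methoxy in place.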